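The compounds below may be only part of what the source reports. "The series", "measured", "known", "first", "only" and "open" are said of these compounds alone.

- compound 1 `COc1cc(/C=C/C(=O)c2cccc(NC(=O)c3c(Cl)cccc3Cl)c2)ccc1O` gives 17.8 ug/mL
- compound 2 `COc1cc(/C=C/C(=O)c2cccc(N)c2)ccc1O` gives 7.71 ug/mL

In a functional assay on U-87MG ATCC cells (Homo sapiens) for inhibition (on this read-out higher numbers stand for weaker inhibition and lower numbers for stronger inhibition), compound 2 has the lower of the two numbers, 7.71 ug/mL, which makes it the stronger inhibitor of this pair. Compound 3 `COc1cc(/C=C/C(=O)c2cccc(NC(=O)c3ccc(Cl)cc3Cl)c2)ccc1O` differs from compound 2 in one place, with (2,4-dichlorophenyl)carbonyl in place of hydrogen on a nitrogen on an aromatic ring. Among the measured compounds shown here, only one measured step bears on this change: a 2.3-fold lower number from compound 1 to compound 2 (0.36 log units; beyond the scatter), where (2,6-dichlorophenyl)carbonyl on that nitrogen gave way to hydrogen. Compound 3 gains a closely similar group, so that modest step, read in reverse, suggests a rise of about the same size in this assay, though this rests on a single pair. The expected change is a 2.1-fold higher number from compound 2 to compound 3 (0.32 log units; beyond the scatter), towards weaker inhibition. For compound 3 the estimated value is 16 ug/mL, with an expected range from 8 ug/mL to 32 ug/mL.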

Compound 3, half-maximal inhibitory concentration: > 50 ug/mL
Compound 3 was reported as a limit (the forecaster's own chance of this, stated with the estimate: 3%); middle value at least 3.1-fold (0.49 log units) from the limit.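

On the nitrogen on an aromatic ring, a dichlorinated acyl group can cost more than compound 1 alone suggested: in this assay, (2,4-dichlorophenyl)carbonyl in place of hydrogen gives an at least 6.4-fold higher number from compound 2 to compound 3 (0.81 log units; beyond the scatter). Putting 2,4-dichlorophenyl in place of 2,6-dichlorophenyl on the carbonyl carbon gives an at least 2.8-fold higher number from compound 1 to compound 3 (0.44 log units; beyond the scatter), so these two groups are not interchangeable here, and where the chlorines sit matters as well as whether they are present. Compound 3 is reported only as a limit and not as an exact number: the limit of > 50 ug/mL in this assay, at which 1 of the 3 values shown sits.

As far as these compounds go, how far compound 3 lies past that limit remains open, and with it the true size of both steps. Also open, from the compounds shown here alone, is whether a simple acetyl or methyl group on this nitrogen would stay close to compound 2 or also raise the number.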